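Chloro to Methylcarbamoyl in a Series Resting at the Limit

The compounds below may be only part of what the source reports. "The series", "measured", "known", "first", "only" and "open" are said of these compounds alone.

Compound 1, `O=C(CCCCCCc1ccccc1)c1ncno1`, gives in an assay on HEK-293T cells for inhibition of diacylglycerol lipase-alpha (Homo sapiens), read by colorimetric assay (on this read-out higher numbers stand for weaker inhibition and lower numbers for stronger inhibition), only a limit, > 10000 nM.
Compound 2, `CC(=O)c1cnc(C(=O)CCCCCCc2ccccc2)o1`, gives in this assay only a limit, > 10000 nM.
Compound 3, `O=C(CCCCCCc1ccccc1)c1ncc(Cl)o1`, gives in this assay only a limit, > 10000 nM.

These three values share one feature: each is a limit of this assay rather than a number, and (the limit of > 10000 nM in this assay, at which 3 of the 3 values shown sit). Compound 3 therefore stands nowhere distinct on the numbers shown; it rests at the same limit as the others. The two measured steps, a step that the two limits leave unreadable from compound 1 to compound 3 and a step that the two limits leave unreadable from compound 2 to compound 3, cannot be sized: both of their ends are limits.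

Compound 4, `CNC(=O)c1cnc(C(=O)CCCCCCc2ccccc2)o1`, has not yet been measured. It differs from compound 3 in one place: methylcarbamoyl in place of chloro on an aromatic carbon. The closest measured comparison is compound 2, which the step that the two limits leave unreadable from compound 2 to compound 3 links to compound 3 through chloro in place of acetyl, and compound 2 likewise reaches only the limit. Among the measured compounds shown here, no measured step here shows a readable change in either direction, so no step beyond the scatter can be expected with confidence, and the most likely outcome is that compound 4 again reaches only the limit. Compound 4 is estimated at 15000 nM, with a range from 4000 nM to 60000 nM. This estimate means an expected step that the limit leaves unreadable from compound 3 to compound 4, within the scatter.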

Compound 4, half-maximal inhibitory concentration: > 10000 nM
Compound 4: a limit, no number (the forecaster's own chance of this, stated with the estimate: 80%); the middle value does not contradict the limit.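

Compound 4 also gives only a limit in this assay, so no size can be read for its steps from compound 2 or compound 3, and every compound shown ends at the same point: the limit of > 10000 nM in this assay, at which 4 of the 4 values shown sit. The compounds shown leave open how strongly each one inhibits, and whether exchanging chloro, acetyl and methylcarbamoyl changes inhibition at all.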